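Compound 3 to Compound 4: One Methyl, Same Limit

The source may hold more compounds than are shown below. What is called first, only, known or untested is meant among the compounds shown, and "the series" means these compounds.

Compound 1, `COC(=O)[C@@H](NC(=O)c1ccc(/C=C2\SC(=O)N(CC(=O)NOCc3ccccc3)C2=O)cc1)C(C)C`, gives > 128000 nM in a functional assay on MRC5 cells (Homo sapiens) for inhibition, read by microscopy and resazurin assay, with a stated time of 72 h; on this read-out lower numbers stand for stronger inhibition and higher numbers for weaker inhibition.
Compound 2, `C=CCONC(=O)Cn1cc(C(=O)NCC(=O)N[C@H](C(=O)O)C(C)C)c2ccccc21`, gives > 128000 nM in this assay.
Compound 3, `C=CCONC(=O)Cn1ccc(C(=O)NCC(=O)N[C@@H](CC(C)C)C(=O)O)c1`, gives > 128000 nM in this assay.

Each of these three values is a limit of the assay and not a measured number. Compound 3 thus stands at a limit, and on the numbers shown it cannot be set apart from the other two. Taken together, the three values sit at the limit of > 128000 nM in this assay, at which 3 of the 3 values shown sit, so no measured step between any two of them is available, and nothing here separates one structure from another.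

Compound 4, `C=CCONC(=O)Cn1ccc(C(=O)N[C@@H](C)C(=O)N[C@@H](CC(C)C)C(=O)O)c1`, has not yet been measured. It differs from compound 3 in one place: methyl in place of hydrogen on a saturated chain carbon bound to an amide-type nitrogen and a carbonyl carbon. For the measured compounds named here, no step between measured compounds bears on this change, and the only guide is that compound 3 gives > 128000 nM. On that basis the expected step of a number no higher from compound 3 to compound 4 (the limit leaves the size open) is none beyond the scatter, with the added methyl not expected to lift the result off the limit. Compound 4 is therefore estimated to give 128000 nM in this assay, within a range from 50000 nM to 400000 nM, and most likely again reported only as a limit.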

Compound 4, half-maximal inhibitory concentration: > 128000 nM
Compound 4: no number, only a limit (the forecaster's own chance of this, stated with the estimate: 85%); the middle value sits exactly at the limit.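

For the compounds shown here, compound 3 and compound 4 are both reported only as limits, so no step between them can be read in this assay, and the methyl in place of hydrogen cannot be given a size. The compounds shown all stand at one point: the limit of > 128000 nM in this assay, at which 4 of the 4 values shown sit. They leave open how far any of these compounds lies past that limit, and whether the methyl changes the result at all.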